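The compounds below may be only part of what the source reports. "The series", "measured", "known", "first", "only" and "open" are said of these compounds alone.

Measured so far:
- compound 1 `O=C(CCCCC1CCSS1)NCc1cn(CCCCCOc2ccc3cc(-c4ccccc4)c(=O)oc3c2)nn1` gives 35.5% in a functional assay on PC-12 cells (Rattus norvegicus) for cytotoxicity, read by MTT assay, with stated times of 3 h and 2 h, tested at 0.1 uM; a lower number here means a weaker effect, a higher number a stronger effect of the compound at the concentration tested
- compound 2 `COc1ccc(-c2cc3ccc(OCCCCCn4cc(CNC(=O)CCCCC5CCSS5)nn4)cc3oc2=O)cc1` gives 34.5% in this assay

Compound 2 stands within the scatter of compound 1, the only other number shown, so the two are not separable. Compound 3 `COc1ccc(-c2cc3ccc(OCCCCCn4cc(CNC(=O)CCCCC5CCSS5)nn4)cc3oc2=O)cc1OC` differs from compound 2 by methoxy in place of hydrogen on an aromatic carbon. Among the compounds with values here, the one step that bears on this is the earlier methoxy addition, a number 1 percentage points lower from compound 1 to compound 2 (within the scatter), which did not move the read-out beyond the scatter. A second methoxy is therefore expected to give no step beyond the scatter, a number 0.5 percentage points lower from compound 2 to compound 3 (within the scatter). Compound 3 is estimated at 34%, between 24% and 44%.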

Compound 3, a percentage reported as activity, at one concentration (the size of the read-out at that concentration, not a potency): 38.5%
For compound 3 the middle estimate is 4.5 percentage points below the measured one; the range from low to high includes it.
By their numbers in this assay, from the lowest: compounds 2, 1 and 3 (each within the scatter of the next).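

Placing a second methoxy on the ring, 4-methoxyphenyl to 3,4-dimethoxyphenyl, stays within the scatter in this assay (a number 4 percentage points higher from compound 2 to compound 3 (within the scatter)). The full change from phenyl to 3,4-dimethoxyphenyl also stays within it (a number 3 percentage points higher from compound 1 to compound 3 (within the scatter)), so on this ring neither one nor two methoxy groups separates from the unsubstituted phenyl of compound 1. No supporting data bear on this result.

Going by these compounds, whether an amine or a carboxylic acid at this position would move the read-out remains open, as does the effect of a longer linking chain.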